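Benzylsulfanyl substitution: chloro to trifluoromethyl in a sulfonylguanidine series

This account rests on a few compounds, and the source may have more. Where it says the series, first, only, none or still open, it means among the compounds named here.

Measured in an ADME assay on HaCaT cells (Homo sapiens) for cytotoxicity, read by MTT assay, with a stated time of 72 h; a lower number here means a stronger inhibitor, a higher number a weaker inhibitor:
- compound 1 `Cc1cc(S(=O)(=O)/N=C(\N)n2nccc2-c2ccccc2)c(SCc2cccc(Cl)c2)cc1Cl`: 10000 nM
- compound 2 `Cc1cc(S(=O)(=O)/N=C(\N)n2nccc2-c2ccccc2)c(SCc2ccccc2)cc1Cl`: 18000 nM
- compound 3 `Cc1cc(-c2ccccc2)n(/C(N)=N/S(=O)(=O)c2cc(C)c(Cl)cc2SCc2ccccc2)n1`: 10000 nM

On these numbers compound 2 cannot be set apart from compound 1 or compound 3: both lie within the scatter of it. Compound 4 `Cc1cc(S(=O)(=O)/N=C(\N)n2nccc2-c2ccccc2)c(SCc2cccc(C(F)(F)F)c2)cc1Cl` is compound 2 with trifluoromethyl in place of hydrogen on an aromatic carbon. The step that bears most directly on this change is the removal of chloro at the same place, a 1.8-fold higher number from compound 1 to compound 2 (0.26 log units; within the scatter), which stayed within the scatter. The other step, a 1.8-fold lower number from compound 2 to compound 3 (0.26 log units; within the scatter), sits elsewhere on the scaffold and was likewise within the scatter. Neither gives ground for a movement beyond the scatter in this assay. For compound 4 the step of a 1.6-fold lower number from compound 2 to compound 4 (0.21 log units; within the scatter) is expected. Compound 4 is estimated at 11000 nM, within 5000 nM to 25000 nM.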

Compound 4, half-maximal inhibitory concentration: 18000 nM
Estimate against measurement, compound 4: 1.6-fold (0.21 log units) below; the measured number falls inside the stated range.
By their numbers in this assay, from the lowest: compounds 1, 3, 2 and 4 (each within the scatter of the next).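

On this aromatic carbon, trifluoromethyl and hydrogen give the same reading in this assay, with no change at the digits printed from compound 2 to compound 4 (within the scatter) as the step. Trifluoromethyl in place of chloro gives a 1.8-fold higher number from compound 1 to compound 4 (0.26 log units; within the scatter), so hydrogen, chloro and trifluoromethyl cannot be told apart here, and a group of several heavy atoms at this place shows no movement beyond the scatter. Nothing available explains this flat reading. On these data alone, whether an amine or a carboxylic acid at this place would leave the reading unchanged stays open. So does whether trifluoromethyl behaves alike on the core of compound 3.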